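Cytotoxicity notes on an anilide series: acetyl replaces sulfamoyl

The compounds below may be only part of what the source reports. "The series", "measured", "known", "first", "only" and "open" are said of these compounds alone.

The series shares a core carrying a naphthyl-substituted triazine linked through a thioacetamide to an aniline. Compound 1 `O=C(CSc1nncnc1-c1cccc2ccccc12)Nc1ccccc1` is the unsubstituted anilide. In an ADME assay on MT4 cells (Homo sapiens) for cytotoxicity, read by MTT assay (a higher number here means that more compound is tolerated, a lower number that less compound is tolerated), compound 1 gives 154000 nM. Compound 2 `NS(=O)(=O)c1ccc(NC(=O)CSc2nncnc2-c2cccc3ccccc23)c(Br)c1` carries a bromo group and a sulfamoyl group on the anilide ring. In this assay compound 2 gives 23000 nM, the lowest of the two numbers seen so far; compound 1 sits higher, and the gap between the two lies beyond the usual scatter. Within the data shown here, no step between compounds differing in one place has been measured, so the data give no direct read on what either group on the anilide ring does on its own.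

Compound 3 `CC(=O)c1ccc(NC(=O)CSc2nncnc2-c2cccc3ccccc23)c(Br)c1` is compound 2 altered in one place: acetyl in place of sulfamoyl on an aromatic carbon. Given only the two numbers above, no step beyond the scatter is expected in this assay from this change. Compound 3 is estimated at 30000 nM, within 8000 nM to 110000 nM, which means an expected step of a 1.3-fold higher number from compound 2 to compound 3 (0.12 log units; within the scatter).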

Compound 3, half-maximal cytotoxic concentration: 133000 nM
Estimate against measurement, compound 3: 4.4-fold (0.65 log units) below; the whole stated range lies below it.
By their numbers in this assay, from the lowest: compound 2; then compounds 3 and 1 (each within the scatter of the next).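

In this assay, among these compounds, the change at the aromatic carbon para to a large group and meta to a bromo group, acetyl in place of sulfamoyl, gives a 5.8-fold higher number from compound 2 to compound 3 (0.76 log units; beyond the scatter) and is the first single-place step, showing that the group at this position can move the number beyond the scatter. The step to the unsubstituted anilide adds to this: 4-acetyl-2-bromophenyl in place of phenyl on the amide-type nitrogen gives a 1.2-fold lower number from compound 1 to compound 3 (0.06 log units; within the scatter) and stays within the scatter, so in this pair the bromo and acetyl groups together leave the number unresolved from that of the plain anilide, and the gap seen earlier for compound 2 goes with sulfamoyl in these compounds. No measurement available on these compounds bears on why the exchange has this size.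

The compounds shown leave open what the bromo group does on its own, since acetyl and sulfamoyl appear here only together with it. They also leave open whether an amine, a carboxylic acid or a longer acyl chain at this position would read like sulfamoyl or like acetyl in this assay on this anilide ring.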